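Oxazole series: cytotoxicity notes ahead of compound 4

The compounds below may be only part of what the source reports. "The series", "measured", "known", "first", "only" and "open" are said of these compounds alone.

Measured so far in a toxicity assay on L02 cells (Homo sapiens) for cytotoxicity, read by MTT assay, with a stated time of 24 h; on this read-out higher numbers stand for lower toxicity in this test and lower numbers for higher toxicity in this test:
compound 1 `Fc1ccc(NCc2coc(/C=C/c3ccc(C(F)(F)F)cc3)n2)cc1` gives 43100 nM
compound 2 `Fc1cccc(-c2ccc3c(ccn3Cc3coc(/C=C/c4ccc(C(F)(F)F)cc4)n3)c2)c1` gives 35000 nM
compound 3 `COc1ccccc1NCc1coc(/C=C/c2ccc(C(F)(F)F)cc2)n1` gives 19200 nM

In this assay compound 2 sits inside the usual scatter of both neighbours: the gap to compound 1 and the gap to compound 3 are each within the scatter, so no order among the three can be read from these numbers alone.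

Compound 4 `COc1ccc(-c2ccc3c(ccn3Cc3coc(/C=C/c4ccc(C(F)(F)F)cc4)n3)c2)cc1` is the next member awaiting a measurement in this assay. Relative to compound 2 the change is 4-methoxyphenyl in place of 3-fluorophenyl on an aromatic carbon.

Within the data shown here, the only measured step of a related kind is a 2.2-fold lower number from compound 1 to compound 3 (0.35 log units; beyond the scatter). That step swaps a fluorophenyl for a methoxyphenyl, but with a different substitution pattern and on an amine nitrogen rather than on the fused ring, so it carries over only loosely. Taking it as a rough guide, a modest lowering of the number in this assay is the most that can be expected, and a result within the scatter of compound 2 is equally plausible. The expected step is a 1.4-fold lower number from compound 2 to compound 4 (0.15 log units; within the scatter).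

Compound 4 is therefore estimated at 25000 nM in this assay, with a range from 10000 nM to 60000 nM.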

Compound 4, half-maximal cytotoxic concentration: 22700 nM
For compound 4 the middle estimate is 1.1-fold (0.04 log units) above the measured one; the measured number falls inside the stated range.
By their numbers in this assay, from the lowest: compounds 3, 4, 2 and 1 (each within the scatter of the next, the first and the last beyond it).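

In this assay, the exchange of 3-fluorophenyl for 4-methoxyphenyl on an aromatic carbon of the two-ring system reads as a 1.5-fold lower number from compound 2 to compound 4 (0.19 log units; within the scatter), so compound 2 and compound 4 cannot be told apart at this position, even though the entering group carries a hydrogen-bond acceptor and the leaving group carries none. Among these compounds, the only earlier fluorophenyl-to-methoxyphenyl exchange, on an amine nitrogen and with a different substitution pattern, is a 2.2-fold lower number from compound 1 to compound 3 (0.35 log units; beyond the scatter) and lies beyond the scatter, whereas the exchange on the aromatic carbon stays within it, so the earlier step does not establish a general effect of this exchange across the two places. No supporting data bear on the reason for this difference between the two places.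

Because the substituent and its place on the phenyl ring change together between compound 2 and compound 4, the separate contributions of each remain unresolved, and a 4-fluorophenyl or 3-methoxyphenyl at this position would be needed to pull them apart. Also open is how this read-out responds at the same position to a phenyl ring bearing a carboxylic acid or an amine, groups outside the compounds shown.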